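Ester replacements on the aryl oxygen: cytotoxicity notes

The source may report more compounds than this note shows. Statements on the series, on what has been measured and on what is new or still open speak of the compounds shown alone.

Measured compounds:
Compound 1 `COc1ccc(/C=C/C(=O)c2ccc(OC)c3c2OC(C)(C)C=C3)cc1OCC=C(C)C` in an ADME assay on L02 cells (Homo sapiens) for cytotoxicity, read by MTT assay (a lower number here means a stronger inhibitor, a higher number a weaker inhibitor), gives > 10000 nM, a limit of the assay.
Compound 2 `COc1ccc(/C=C/C(=O)c2ccc(OC)c3c2OC(C)(C)C=C3)cc1OC(=O)C1CC1` gives > 10000 nM, likewise a limit.
Compound 3 `COc1cccc(C(=O)Oc2cc(/C=C/C(=O)c3ccc(OC)c4c3OC(C)(C)C=C4)ccc2OC)c1` gives > 10000 nM, also a limit.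

Compound 1 therefore stands only at a limit, and the same holds for compounds 2 and 3: the limit of > 10000 nM in this assay, at which 3 of the 3 values shown sit. The steps a step that the two limits leave unreadable from compound 1 to compound 2, a step that the two limits leave unreadable from compound 1 to compound 3 and a step that the two limits leave unreadable from compound 2 to compound 3 are all unreadable, since both ends sit at the limit.

Compound 4 `COc1ccc(/C=C/C(=O)c2ccc(OC)c3c2OC(C)(C)C=C3)cc1OC(=O)c1ccco1` differs from compound 1 by (furan-2-yl)carbonyl in place of 3-methylbut-2-en-1-yl on an oxygen on an aromatic ring. The two measured steps from compound 1 exchange the same leaving group for a carbonyl-bearing group and gave nothing readable, so no step beyond the scatter is expected for compound 4 in this assay, that is a step that the limit leaves unreadable from compound 1 to compound 4. Compound 4 is expected near 15000 nM, within 8000 nM to 40000 nM, most likely reported again only as a limit.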

Compound 4, half-maximal inhibitory concentration: > 10000 nM
Compound 4: a limit, no number (the forecaster's own chance of this, stated with the estimate: 85%); the middle value is on the limit's open side.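

Compound 4, like compound 1, compound 2 and compound 3, is reported only as a limit, so no step among them can be read: the limit of > 10000 nM in this assay, at which 4 of the 4 values shown sit.

The compounds shown leave open how these four actual values compare in this assay and whether any replacement on the aryl oxygen changes cytotoxicity.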